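Trimming the ring-nitrogen substituent down to hydrogen

The compounds below may be only part of what the source reports. "The series", "measured", "known", "first", "only" and "open" are said of these compounds alone.

Measured compounds:
- compound 1, `CCN1C[C@@H]2[C@H](C1)[C@H]2CN(Cc1cccc(Cl)c1)C(=O)c1cn(C)cn1`: 4.58 nM
- compound 2, `CN1C[C@@H]2[C@H](C1)[C@H]2CN(Cc1cccc(Cl)c1)C(=O)c1cn(C)cn1`: 11 nM

Among the measured compounds shown here, in an assay on isolated protein for binding affinity to sodium- and chloride-dependent glycine transporter 1 (Homo sapiens) (a higher number here means a weaker inhibitor, a lower number a stronger inhibitor), compound 2 gives 11 nM, the higher of the two numbers measured so far; its nearest neighbour, compound 1, gives 4.58 nM in this assay. For the measured compounds named here, the one measured step between them, a 2.4-fold higher number from compound 1 to compound 2 (0.38 log units; beyond the scatter), shows that shortening the group on the amine nitrogen in the ring by one carbon made the inhibitor modestly weaker.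

Compound 3, `Cn1cnc(C(=O)N(Cc2cccc(Cl)c2)C[C@H]2[C@@H]3CNC[C@@H]32)c1`, has not been measured in this assay. It differs from compound 2 by hydrogen in place of methyl on an amine nitrogen in a ring. This is the same kind of change carried one carbon further: the substituent on that amine nitrogen shrinks again, this time to nothing but hydrogen. Going by the values given here, only one measured step bears on it, and that step went toward a higher number. Among the compounds with values here, a step of similar size in the same direction is therefore expected, a 2.4-fold higher number from compound 2 to compound 3 (0.37 log units; beyond the scatter), though with only one precedent the spread is wide. For compound 3 the estimated value in this assay is 26 nM, with a range from 8 nM to 85 nM.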

Compound 3, inhibition constant: 95.3 nM
Beside the measured number, compound 3's estimate is 3.7-fold (0.56 log units) below it; the measured number lies above the stated range.
By their numbers in this assay, from the lowest: compound 1; then compound 2; then compound 3.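

In this assay, taking away the last carbon on the amine nitrogen in the ring gives an 8.7-fold higher number from compound 2 to compound 3 (0.94 log units; beyond the scatter) and this is a bigger jump than the earlier shortening from ethyl to methyl, which gave a 2.4-fold higher number from compound 1 to compound 2 (0.38 log units; beyond the scatter). Over the whole change, hydrogen in place of ethyl gives a 21-fold higher number from compound 1 to compound 3 (1.32 log units; beyond the scatter) so the number rises at each step along these three compounds, none going against the trend, and most of the loss comes when the nitrogen is left with no carbon substituent at all. Nothing available here explains why the bare nitrogen costs so much more than the shorter chain.

Only ethyl, methyl and hydrogen are shown at this position, so it remains open whether the trend continues toward a stronger inhibitor with a longer chain such as propyl or butyl, or whether it levels off or reverses. On these data alone, it is also open how a ring-bearing group such as cyclopropylmethyl or benzyl on this nitrogen would fare in this assay with the rest of the molecule kept the same.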